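Swapping the aryl group on the sulfonamide nitrogen

The source may hold more compounds than are shown below. What is called first, only, known or untested is meant among the compounds shown, and "the series" means these compounds.

Compound 1 `O=C1NCCN1c1ccc(S(=O)(=O)Nc2ccc(F)cc2)cc1` gives 230 nM in a functional assay on M21 cells (Homo sapiens) for antiproliferative activity, read by sulforhodamine B assay, with a stated time of 48 h (a higher number here means a weaker inhibitor, a lower number a stronger inhibitor), the lowest of the numbers shown. Compound 3 `CCCCOc1ccc(NS(=O)(=O)c2ccc(N3CCNC3=O)cc2)cc1` gives 580 nM in this assay, so butoxy in place of fluoro brought a 2.5-fold higher number from compound 1 to compound 3 (0.40 log units; beyond the scatter). Compound 2 `CCCCCCCc1ccc(NS(=O)(=O)c2ccc(N3CCNC3=O)cc2)cc1` reaches only the limit of this assay, > 1000 nM, which is a limit rather than a number. Heptyl in place of fluoro thus brought an at least 4.3-fold higher number from compound 1 to compound 2 (0.63 log units; beyond the scatter). Compound 4 `Cc1cccc(NS(=O)(=O)c2ccc(N3CCNC3=O)cc2)c1C` has not yet been measured; it differs from compound 1 by 2,3-dimethylphenyl in place of 4-fluorophenyl on a sulfonamide nitrogen. Both measured replacements of the fluoro weakened inhibition, so a modest weakening is expected here too, a 2.0-fold higher number from compound 1 to compound 4 (0.29 log units; within the scatter). Compound 4 is therefore estimated to give about 450 nM, with a likely range from 200 nM to 1000 nM.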

Compound 4, half-maximal inhibitory concentration: 110 nM
Estimate against measurement, compound 4: 4.1-fold (0.61 log units) above, and the stated range ends above it.
By their numbers in this assay, from the lowest: compound 4; then compound 1; then compound 3. At a limit, above all of these: compound 2.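

In this assay, the step with 2,3-dimethylphenyl in place of 4-fluorophenyl on a sulfonamide nitrogen is a 2.1-fold lower number from compound 1 to compound 4 (0.32 log units; beyond the scatter), so a change at this position can strengthen inhibition as well as weaken it. Compound 2 and compound 3 had shown only weakening, and compound 4 goes against that pattern. Nothing shown here accounts for this gain. From the compounds shown here alone, it remains open whether one methyl group would be enough, and how an aryl group carrying an amine or a carboxylic acid would compare.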